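Compound 4: methylcarbamoyl gives way to 1H-1,2,4-triazol-1-yl

A few compounds are considered here, and "the series" means these few. Any claim that something is new, unique, unknown or untested is made for them only; others in the source may bear on it.

Values from an ADME assay on S9 fraction from liver (Homo sapiens) for metabolic stability, with a stated time of 1 h (a lower number here means that less of the compound is left, a higher number that more of the compound is left), for the measured compounds are these
- compound 1 `N#Cc1cnc(NCc2cnccc2C(F)(F)F)cc1N[C@H]1CC[C@H](O)CC1` gives 30%
- compound 2 `N#Cc1cnc(NCc2cnccc2C(F)(F)F)cc1NC[C@H]1CC[C@@H](O)CC1` gives 41%
- compound 3 `CNC(=O)[C@H]1CC[C@@H](Nc2cc(NCc3cnccc3C(F)(F)F)ncc2C#N)CC1` gives 71%

Compound 3 stands highest of the three, beyond the scatter from both others. Compound 4 `N#Cc1cnc(NCc2cnccc2C(F)(F)F)cc1N[C@H]1CC[C@@H](n2cncn2)CC1` carries 1H-1,2,4-triazol-1-yl in place of methylcarbamoyl on a saturated ring carbon. Among the measured compounds shown here, two measured steps bear on this change, a number 41 percentage points higher from compound 1 to compound 3 (beyond the scatter) and a number 30 percentage points higher from compound 2 to compound 3 (beyond the scatter) (both arrive at methylcarbamoyl). For the measured compounds named here, they show that swapping this group can shift the number considerably, yet no measured compound carries the triazolyl group. In this assay a modest fall from compound 3 is therefore expected, though the direction is uncertain. The expected change is a number 13 percentage points lower from compound 3 to compound 4 (beyond the scatter) (an estimate). Compound 4 is estimated at 58% (expected range 35% to 80%).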

Compound 4, percent of the compound remaining: 64%
Compound 4: middle estimate off by 6 percentage points, on the low side, and the stated range covers the measured number.
By their numbers in this assay, from the lowest: compound 1; then compound 2; then compounds 4 and 3 (each within the scatter of the next).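

In this assay the change to 1H-1,2,4-triazol-1-yl gives a number 7 percentage points lower from compound 3 to compound 4 (within the scatter), so at this saturated ring carbon a five-membered aromatic ring with no hydrogen-bond donor reads the same as methylcarbamoyl, which has one. The amide hydrogen is therefore not needed to keep the number at this level. No measurement shown explains why these two different groups read alike.

From the compounds shown here alone, whether this extends beyond these two groups stays open. An amine, a carboxylic acid or a tetrazole on the same carbon could give quite a different number.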